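The source may hold more compounds than are shown below. What is called first, only, known or untested is meant among the compounds shown, and "the series" means these compounds.

Three compounds on the shared core have been run in a functional assay on HeLa cells (Homo sapiens) for cytotoxicity, read by MTT assay, with a stated time of 48 h; a lower number here means a stronger inhibitor, a higher number a weaker inhibitor. Compound 1 `Cc1ccc(S(=O)(=O)/N=C(/CCNC2=CC(=O)c3ccccc3C2=O)Nc2ccc(Cl)cc2)cc1` gives 13400 nM. Compound 2 `Cc1ccc(S(=O)(=O)/N=C(/CCNC2=CC(=O)c3ccccc3C2=O)Nc2ccccc2I)cc1` gives 19100 nM. Compound 3 `Cc1ccc(S(=O)(=O)/N=C(/CCNC2=CC(=O)c3ccccc3C2=O)Nc2cccc(C)c2)cc1` gives 9060 nM, the lowest of the three numbers shown; a 1.5-fold lower number from compound 1 to compound 3 (0.17 log units; within the scatter) stays within the scatter, while a 2.1-fold lower number from compound 2 to compound 3 (0.32 log units; beyond the scatter) is modest but beyond it, and a 1.4-fold higher number from compound 1 to compound 2 (0.15 log units; within the scatter) is within the scatter. Across these three, exchanging the group on the amine nitrogen has moved the numbers only a little.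

Compound 4 `Cc1ccc(S(=O)(=O)/N=C(/CCNC2=CC(=O)c3ccccc3C2=O)Nc2cccc(C(F)(F)F)c2)cc1` differs from compound 3 in one place: trifluoromethyl in place of methyl on an aromatic carbon. Among the measured compounds shown here, no measured step exchanges methyl for trifluoromethyl, so the only guide is the set of swaps on the same aromatic ring, all of which stayed within or just beyond the scatter. The step of a 1.0-fold lower number from compound 3 to compound 4 (0.00 log units; within the scatter) is therefore expected to be small, with no confident direction. Compound 4 is estimated at 9000 nM, with a range from 4500 nM to 18000 nM.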

Compound 4, half-maximal inhibitory concentration: 77600 nM
Compound 4: the middle estimate sits 8.6-fold (0.94 log units) below what was measured, and the stated range ends below it.
By their numbers in this assay, from the lowest: compounds 3, 1 and 2 (each within the scatter of the next, the first and the last beyond it); then compound 4.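

In this assay, among the compounds shown here, this aromatic carbon proves sensitive to the group it carries: an 8.6-fold higher number from compound 3 to compound 4 (0.93 log units; beyond the scatter) is the largest step so far, although the earlier exchanges of the whole aryl group stayed within or only just beyond the scatter. The 3-(trifluoromethyl)phenyl group also separates from the other two aryl groups, with a 4.1-fold higher number from compound 2 to compound 4 (0.61 log units; beyond the scatter) and a 5.8-fold higher number from compound 1 to compound 4 (0.76 log units; beyond the scatter), so compound 4 now has the highest number of the four, beyond the scatter from each of the others. For the compounds shown here, nothing available bears on why this exchange shifts the number so far.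

As far as these compounds go, whether chloro, methoxy or ethyl on the same carbon would track with methyl or with trifluoromethyl remains open. Also open, from the compounds shown here alone, is whether trifluoromethyl on another carbon of this aromatic ring would give a similar step.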